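The source may report more compounds than this note shows. Statements on the series, on what has been measured and on what is new or still open speak of the compounds shown alone.

The measured compounds are as follows. Compound 1, `COc1ccc(-c2cc(/C=C/C(=O)c3ccc(N)cc3)[nH]n2)cc1`, gives 61200 nM in a functional assay on HOP-62 cells (Homo sapiens) for inhibition, read by sulforhodamine B assay, with a stated time of 48 h; on this read-out higher numbers stand for lower toxicity in this test and lower numbers for higher toxicity in this test. Compound 2, `COc1ccc(C(=O)/C=C/c2cc(-c3cc(OC)c(OC)c(OC)c3)n[nH]2)cc1OC`, gives 5350 nM. Compound 3, `COc1ccc(-c2cc(/C=C/C(=O)c3ccc(N)cc3)[nH]n2)cc1OC`, gives 32000 nM.

Compound 2 has the lowest number of the three, and its distance from both other compounds is beyond the scatter. Compound 1 and compound 3 share a core; compound 3 carries methoxy in place of hydrogen on an aromatic carbon, and that step was a 1.9-fold lower number from compound 1 to compound 3 (0.28 log units; within the scatter). Compound 2 and compound 1 differ in more than one place, and the difference between the two cores is not broken down here.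

Compound 4, `COc1cc(C(=O)/C=C/c2cc(-c3cc(OC)c(OC)c(OC)c3)n[nH]2)cc(OC)c1OC`, has not yet been measured. It differs from compound 2 by methoxy in place of hydrogen on an aromatic carbon. Among the compounds with values here, this is the same kind of change as the one from compound 1 to compound 3, but the surroundings are not identical: in compound 4 the entering methoxy is also meta to a methoxy group, which was not so in compound 3. Because the earlier step was a 1.9-fold lower number from compound 1 to compound 3 (0.28 log units; within the scatter), a small step is expected here too, estimated as a 1.3-fold lower number from compound 2 to compound 4 (0.13 log units; within the scatter). Compound 4 is therefore expected to give about 4000 nM, likely between 1500 nM and 12000 nM.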

Compound 4, concentration lethal to 50% of the cells: 5740 nM
Estimate against measurement, compound 4: 1.4-fold (0.16 log units) below; the range from low to high includes it.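

Replacing hydrogen with methoxy on an aromatic carbon gives a step that stays within the scatter in this assay: a 1.1-fold higher number from compound 2 to compound 4 (0.03 log units; within the scatter). Set beside the earlier example of this change, the two steps cannot be told apart: the same change on two cores in this assay, a 1.9-fold lower number (0.28 log units; within the scatter) from compound 1 to compound 3 and a 1.1-fold higher number (0.03 log units; within the scatter) from compound 2 to compound 4, 2.1-fold (0.31 log units) apart, within the scatter of two such steps. On these two cores, then, the methoxy change gave only a small step each time, but two pairs do not prove that its effect is identical on both cores, do not establish a rule for the whole series and do not explain the result.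

On these data alone, it remains open whether a hydroxyl group or a carboxylic acid in the same place would give a step beyond the scatter. As far as these compounds go, it is also open whether the methoxy step would stay this small on other cores or in other cell-based tests.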